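A few compounds are considered here, and "the series" means these few. Any claim that something is new, unique, unknown or untested is made for them only; others in the source may bear on it.

Measured so far:
compound 1 `O=C(NC(=S)Nc1ccc(F)cc1)c1cn(-c2ccccc2)nc1-c1ccccc1`, 3500 nM
compound 2 `COc1ccc(NC(=S)NC(=O)c2cn(-c3ccccc3)nc2-c2ccc(OC)cc2)cc1`, 750 nM

In a functional assay on A549 cells (Homo sapiens) for inhibition, read by CCK-8 assay, with a stated time of 48 h (a lower number here means a stronger inhibitor, a higher number a weaker inhibitor), compound 2 gives 750 nM, the lowest of the two numbers. Compound 1 gives 3500 nM in this assay, a gap beyond the usual scatter. Compound 3 `COc1ccc(-c2nn(-c3ccccc3)cc2C(=O)NC(=S)Nc2ccc(F)cc2)cc1` is compound 2 with fluoro in place of methoxy on an aromatic carbon. Among the measured compounds shown here, no pair of measured compounds isolates this change alone, since compound 1 differs from compound 2 at two places. The expected step of a 2.1-fold higher number from compound 2 to compound 3 (0.33 log units; beyond the scatter) is a modest loss, likely beyond the scatter. Compound 3 is estimated at 1600 nM, expected between 600 nM and 4000 nM.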

Compound 3, half-maximal inhibitory concentration: 1430 nM
Beside the measured number, compound 3's estimate is 1.1-fold (0.05 log units) above it; low and high end bracket the measured number.
By their numbers in this assay, from the lowest: compounds 2 and 3 (each within the scatter of the next); then compound 1.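

In this assay the change from (4-methoxyphenyl)amino to (4-fluorophenyl)amino gives a 1.9-fold higher number from compound 2 to compound 3 (0.28 log units; within the scatter) and so does not separate fluoro from methoxy at this position. Methoxy in place of hydrogen on an aromatic carbon at the other site gives a 2.4-fold lower number from compound 1 to compound 3 (0.39 log units; beyond the scatter) as a modest step, the only one of the two beyond the scatter. No independent evidence bears on the size of either step.

As far as these compounds go, whether an amine or a carboxylic acid in place of fluoro would stand apart from these values remains open. So does the effect of a longer chain such as ethoxy in place of methoxy.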